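The compounds below may be only part of what the source reports. "The series", "measured", "known", "first", "only" and "open" are said of these compounds alone.

Measured in an in vitro functional assay on HEK285-7 cells for antagonist activity at prostaglandin D2 receptor 2 (Homo sapiens), read by BRET and beta-arrestin recruitment; on this read-out lower numbers stand for smaller maximal responses and higher numbers for larger maximal responses:
- compound 1, `O=C(O)Cc1sc(Cc2ccccc2)nc1-c1ccc(Cl)cc1`: 50%
- compound 2, `N#Cc1ccc(-c2nc(C(c3ccc(F)cc3)c3ccc(F)cc3)sc2CC(=O)O)cc1`: 30%

Compound 2 stands lowest of the two numbers available; its nearest neighbour is compound 1, whose number is higher by a margin beyond the usual scatter. The two differ in more than one place, so nothing more than the two values themselves can be read from the pair.

The step under consideration goes from compound 2 to compound 3, `O=C(O)Cc1sc(C(c2ccc(F)cc2)c2ccc(F)cc2)nc1-c1cn[nH]c1`, not yet measured in this assay. The change is 1H-pyrazol-4-yl in place of 4-cyanophenyl on an aromatic carbon. It is a single change at one place of the shared core, with the carboxymethyl group and the large group on the core kept as in compound 2.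

Within the data shown here, no step between measured compounds isolates this kind of exchange, so the direction cannot be taken from the series. The expectation is a step from compound 2 to compound 3 of roughly a number 5 percentage points higher from compound 2 to compound 3 (within the scatter), which is within the scatter, with the possibility of a moderate rise not excluded. Compound 3 is accordingly estimated at 35%, within a range from 15% to 60%.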

Compound 3, largest response reached (reported as efficacy), in percent of the reference or control that the assay uses: 80%
The estimate for compound 3 lay 45 percentage points below the measured number; the measured number lies above the stated range.
By their numbers in this assay, from the lowest: compound 2; then compound 1; then compound 3.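

In this assay the aromatic carbon next to the ring nitrogen and next to the ring atom that bears a carboxymethyl group turns out to be a position where the maximal response depends strongly on the group it carries: 1H-pyrazol-4-yl in place of 4-cyanophenyl gives a number 50 percentage points higher from compound 2 to compound 3 (beyond the scatter) with the rest of the molecule unchanged. The earlier pair could not show this, as its two compounds differ in more than one place. The exchange alters the ring size, removes the nitrile and adds a hydrogen-bond donor all at once, and nothing available here indicates which of these matters for the step.

Going by these compounds, it remains open whether the step follows the loss of the nitrile, the five-membered ring or the pyrazole hydrogen; a plain phenyl group at this carbon, or a pyrazole with a methyl group on its nitrogen, would help separate these. On these data alone, it is also open whether the exchange has a similar effect when the two 4-fluorophenyl groups on the large group give way to a simple benzyl group.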